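The source may hold more compounds than are shown below. What is called first, only, known or untested is meant among the compounds shown, and "the series" means these compounds.

Of the compounds shown here, two have so far been tested in a functional assay (strain AB) with Danio rerio as the target, read by microscopy, with a stated time of 1 h; a higher number here means that more compound is needed for the effect, a lower number that less compound is needed. In that assay, compound 1 (`CCN1CCc2c(sc(NC(=S)Nc3ccc(Cl)cc3)c2C(N)=O)C1`) gives 6570 nM, and compound 2 (`CN1CCc2c(sc(NC(=O)Nc3ccc(Cl)cc3)c2C(N)=O)C1`) gives 4700 nM. These two numbers lie within the usual scatter of each other, so compound 2 stands level with compound 1. The next compound, compound 3 (`NC(=O)c1c(NC(=O)Nc2ccc(Cl)cc2)sc2c1CCN(C1CCOCC1)C2`), differs from compound 2 by oxan-4-yl in place of methyl on an amine nitrogen in a ring. Among the measured compounds shown here, no measured pair of compounds shows the effect of a change in this one place, so the expectation rests on little. The expected step is a 1.3-fold higher number from compound 2 to compound 3 (0.11 log units; within the scatter), a modest move towards a higher number that may not clear the scatter. In this assay, the estimated value for compound 3 is 6000 nM, with an expected range from 1800 nM to 20000 nM.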

Compound 3, half-maximal effective concentration: 2830 nM
Compound 3: the middle estimate sits 2.1-fold (0.33 log units) above what was measured; measured number inside the range.
By their numbers in this assay, from the lowest: compounds 3, 2 and 1 (each within the scatter of the next, the first and the last beyond it).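

Among the compounds shown here, this is the first reading at the amine nitrogen in the ring, and it shows that this place accepts far more than a methyl group in this assay. Oxan-4-yl brings a six-membered non-aromatic ring and a hydrogen-bond acceptor that methyl lacks, yet the change gives a 1.7-fold lower number from compound 2 to compound 3 (0.22 log units; within the scatter), so compound 2 and compound 3 stand level. Nothing measured on these compounds offers an explanation for this result.

As far as these compounds go, whether an open chain such as n-butyl, or a group carrying an amine or a carboxylic acid, would also hold this level on the same nitrogen remains open. Compound 1 differs from compound 2 in two places, so it gives no separate reading of either change.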